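This account rests on a few compounds, and the source may have more. Where it says the series, first, only, none or still open, it means among the compounds named here.

Measured in a functional assay on MGC-803 cells (Homo sapiens) for inhibition, read by MTT assay, with a stated time of 72 h; a lower number here means a stronger inhibitor, a higher number a weaker inhibitor:
- compound 1 `Cc1cc(N2CC[C@@H](C)[C@@H](N(C)c3ncnc4[nH]ccc34)C2)n2nc(SCc3ccccc3)nc2n1`: 5870 nM
- compound 2 `Cc1cc(N2CC[C@@H](C)[C@@H](N(C)c3ncnc4[nH]ccc34)C2)n2nc(SCC3CC3)nc2n1`: 9540 nM
- compound 3 `Cc1cc(N2CC[C@@H](C)[C@@H](N(C)c3ncnc4[nH]ccc34)C2)n2nc(SCC3CCCCC3)nc2n1`: 9170 nM

Compound 3, at 9170 nM, lies within the scatter of both compound 1 and compound 2, so these three values do not separate in this assay.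

Next is compound 4 `Cc1cc(N2CC[C@@H](C)[C@@H](N(C)c3ncnc4[nH]ccc34)C2)n2nc(SCc3cc(Cl)ccc3Cl)nc2n1`, which brings 2,5-dichlorophenyl in place of cyclohexyl on a saturated chain carbon bound to a sulfur.

For the measured compounds named here, three measured steps bear on this change. The nearest is a 1.6-fold higher number from compound 1 to compound 3 (0.19 log units; within the scatter), which swaps phenyl for cyclohexyl at the same place and so runs roughly opposite to the change at hand. The other two are a 1.6-fold higher number from compound 1 to compound 2 (0.21 log units; within the scatter) and a 1.0-fold lower number from compound 2 to compound 3 (0.02 log units; within the scatter). All three stay within the scatter, so among compounds 1 to 3 the group at this place has shown no measurable influence. Going by the values given here, no measured compound carries a chlorine substituent, so the data say nothing direct about its contribution.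

A small move towards the value of compound 1 is therefore the best guess, with no clear shift beyond the scatter expected. The expected change is a 1.7-fold lower number from compound 3 to compound 4 (0.22 log units; within the scatter). For compound 4 the estimated value in this assay is 5500 nM, with an expected range of 2200 nM to 12000 nM.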

Compound 4, half-maximal inhibitory concentration: 9850 nM
For compound 4 the middle estimate is 1.8-fold (0.25 log units) below the measured one, within the range that was stated.
By their numbers in this assay, from the lowest: compounds 1, 3, 2 and 4 (each within the scatter of the next).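

In this assay, for the compounds shown here, replacing phenyl with 2,5-dichlorophenyl gives a 1.7-fold higher number from compound 1 to compound 4 (0.22 log units; within the scatter) and thus adds the first direct reading on chlorine substituents at this place, on a saturated chain carbon bound to a sulfur. The comparisons with the saturated rings read the same way: 2,5-dichlorophenyl in place of cyclohexyl gives a 1.1-fold higher number from compound 3 to compound 4 (0.03 log units; within the scatter) and 2,5-dichlorophenyl in place of cyclopropyl gives a 1.0-fold higher number from compound 2 to compound 4 (0.01 log units; within the scatter), so the larger group, with its two chlorine atoms, does not separate from any of the three earlier groups. Cyclopropyl, cyclohexyl, phenyl and 2,5-dichlorophenyl therefore form one unresolved set in this cell assay, and no supporting data explain this flat result for this series.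

On these data alone, all four compounds carry a carbon ring at this place, so it remains open whether an amine, a carboxylic acid or a longer open chain there would give a step beyond the scatter. As far as these compounds go, it is also open whether a change elsewhere on the shared core, such as replacing the methyl group on the saturated nitrogen ring, would move the number more than these exchanges do.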